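This account rests on a few compounds, and the source may have more. Where it says the series, first, only, none or still open, it means among the compounds named here.

Compound 1 is `COc1cc(-n2cnc3ccc(-c4cccc(C)c4C)cc32)cc(OC)c1OC`; in a functional assay on A549 cells (Homo sapiens) for antiproliferative activity, read by MTT assay, with a stated time of 72 h (a higher number here means a weaker inhibitor, a lower number a stronger inhibitor), compound 1 gives 9250 nM.
Compound 2 is `COc1cc(-n2cnc3ccc(-c4ccc(Cl)cc4Cl)cc32)cc(OC)c1OC`; compound 2 reaches only a limit of the assay, > 10000 nM.
Compound 3 is `COc1cc(-n2cnc3ccc(-c4ccc(F)cc4)cc32)cc(OC)c1OC`; compound 3 gives 6740 nM.

Compound 1 gives the highest of the two plain numbers, yet that gap stays within the scatter: a 1.4-fold lower number from compound 1 to compound 3 (0.14 log units; within the scatter). The remaining value is a limit (the limit of > 10000 nM in this assay, at which 1 of the 3 values shown sits), so the step of an at least 1.0-fold higher number from compound 1 to compound 2 (0.03 log units; that floor lies within the scatter) is only a floor. Compound 4, `COc1cc(-n2cnc3ccc(-c4cccc(Cl)c4)cc32)cc(OC)c1OC`, differs from compound 1 in one place: 3-chlorophenyl in place of 2,3-dimethylphenyl on an aromatic carbon. Compound 4 carries a single halogen, as compound 3 does, rather than two as in compound 2, so on the strength of a 1.4-fold lower number from compound 1 to compound 3 (0.14 log units; within the scatter) the expected step is small, a 1.2-fold lower number from compound 1 to compound 4 (0.06 log units; within the scatter). Compound 4 is therefore estimated at 8000 nM, with a range from 4000 nM to 15000 nM.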

Compound 4, half-maximal inhibitory concentration: 7050 nM
Beside the measured number, compound 4's estimate is 1.1-fold (0.05 log units) above it; the range from low to high includes it.
By their numbers in this assay, from the lowest: compounds 3, 4 and 1 (each within the scatter of the next). At a limit, above all of these: compound 2.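

With 3-chlorophenyl on this aromatic carbon, this assay gives a 1.3-fold lower number from compound 1 to compound 4 (0.12 log units; within the scatter) and a 1.0-fold higher number from compound 3 to compound 4 (0.02 log units; within the scatter), so this single chlorine-bearing ring reads the same as both the 2,3-dimethylphenyl and the 4-fluorophenyl rings. The third reading, an at least 1.4-fold lower number from compound 2 to compound 4 (0.15 log units; that floor lies within the scatter), is only a floor. Compound 2 stands at a limit: the limit of > 10000 nM in this assay, at which 1 of the 4 values shown sits.

All the groups shown here are phenyl rings carrying only halogens or methyl groups. As far as these compounds go, whether an amine or a carboxylic acid on that ring would move the number beyond the scatter stays open.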